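The compounds below may be only part of what the source reports. "The series", "measured", "known", "first", "only" and "open" are said of these compounds alone.

Measured in a functional assay on CHO cells for inhibition of transient receptor potential cation channel subfamily V member 1 (Homo sapiens); on this read-out lower numbers stand for stronger inhibition and higher numbers for weaker inhibition:
- compound 1, `O=C(/C=C/c1ccccc1)Nc1ccc2c(c1)OCCO2`: > 4000 nM; this is a limit of the assay, not a number.
- compound 2, `CC(C)c1ccc(/C=C/C(=O)Nc2ccc3c(c2)OCCO3)cc1`: 55 nM
- compound 3, `CCCCc1ccc(/C=C/C(=O)Nc2ccc3c(c2)OCCO3)cc1`: 360 nM

Compound 3 has the highest of the two numbers; the nearest is compound 2, with a 6.5-fold higher number from compound 2 to compound 3 (0.82 log units; beyond the scatter). Compound 1 sits at the limit of > 4000 nM in this assay, at which 1 of the 3 values shown sits.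

Compound 4, `O=C(/C=C/c1ccc(-c2ccccc2)cc1)Nc1ccc2c(c1)OCCO2`, differs from compound 3 by phenyl in place of butyl on an aromatic carbon.

Steps at this same position: an at least 72-fold lower number from compound 1 to compound 2 (1.86 log units; beyond the scatter) and an at least 11-fold lower number from compound 1 to compound 3 (1.04 log units; beyond the scatter) show that any of the groups measured so far lowers the number strongly relative to hydrogen; a 6.5-fold higher number from compound 2 to compound 3 (0.82 log units; beyond the scatter) shows that the kind of group also matters. Among the measured compounds shown here, no measured step puts an aromatic ring at this position, so the size of the change cannot be read from the measured steps. The expectation in this assay is a modest downward step, not confidently beyond the scatter.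

Compound 4 is therefore estimated at 150 nM, expected between 40 nM and 1500 nM. This estimate means a 2.4-fold lower number from compound 3 to compound 4 (0.38 log units; beyond the scatter) is expected.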

Compound 4, half-maximal inhibitory concentration: > 4000 nM
Compound 4 gave a limit, no number; the forecaster's own chance of this, stated with the estimate: 5%; middle value at least 26-fold (1.42 log units) away from the limit.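

Phenyl at this position does not keep what isopropyl and butyl gain: the change gives an at least 11-fold higher number from compound 3 to compound 4 (1.04 log units; beyond the scatter) and, against the branched group, an at least 72-fold higher number from compound 2 to compound 4 (1.86 log units; beyond the scatter). The lowering seen with those two groups therefore does not extend to every group larger than hydrogen, and phenyl, the only ring placed here, is the one of the three that yields no number. Compound 4 gives a limit of the assay and not a number, and the step from compound 1 cannot be read, as both compounds sit at the same limit: the limit of > 4000 nM in this assay, at which 2 of the 4 values shown sit.

Open, from the compounds shown here alone, is whether cyclohexyl or tert-butyl would give a number near that of isopropyl, which would help separate ring from bulk. Also open, going by these compounds, is whether an amine or a methoxy on the added phenyl would restore a measurable number.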